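This account rests on a few compounds, and the source may have more. Where it says the series, first, only, none or still open, it means among the compounds named here.

Measured in an assay for binding affinity to Melanocortin receptor 4 (Homo sapiens); on this read-out higher numbers stand for weaker inhibition and lower numbers for stronger inhibition:
- compound 1, `COc1ccc(Br)cc1CCc1c(F)cccc1C(=O)/N=C(\N)NCCN1CCCC1`: 190 nM
- compound 2, `COc1ccc(Br)cc1CCc1c(F)cccc1C(=O)/N=C(\N)NCCC1CCCCC1`: 2600 nM

Compound 2 stands at the higher of the two numbers in this assay; its nearest neighbour is compound 1, and the step of a 14-fold higher number from compound 1 to compound 2 (1.14 log units; beyond the scatter) separates them, a step that put a carbon-only six-membered ring in place of the pyrrolidin-1-yl group on the saturated chain carbon two bonds from the amine nitrogen.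

Compound 3, `COc1ccc(Br)cc1CCc1c(F)cccc1C(=O)/N=C(\N)NCCCN1CCCCC1`, is not yet measured. It differs from compound 2 as follows: (piperidin-1-yl)methyl in place of cyclohexyl on a saturated chain carbon, two bonds along the chain from an amine nitrogen. The change brings a ring with one nitrogen back onto that chain, while the chain grows by one carbon relative to compound 2 and by one relative to compound 1.

Among the compounds with values here, the only measured step that bears on this is the one from compound 1 to compound 2, which was large and in the weakening direction when the nitrogen-bearing ring was removed. Restoring such a ring is expected to reverse much of that step, so a large decrease in this assay is expected, a 10-fold lower number from compound 2 to compound 3 (1.02 log units; beyond the scatter). The estimate for compound 3 is 250 nM, within 80 nM to 800 nM.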

Compound 3, inhibition constant: 3.2 nM
Compound 3: middle estimate off by 78-fold (1.89 log units), on the high side; measured number outside the range, below it.
By their numbers in this assay, from the lowest: compound 3; then compound 1; then compound 2.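

In this assay, (piperidin-1-yl)methyl in place of cyclohexyl on the saturated chain carbon gives an 810-fold lower number from compound 2 to compound 3 (2.91 log units; beyond the scatter), so this position tolerates far more than the earlier pair showed, and the core of compound 1 can reach the low nanomolar range. The two nitrogen-bearing groups are not interchangeable: (piperidin-1-yl)methyl in place of pyrrolidin-1-yl gives a 59-fold lower number from compound 1 to compound 3 (1.77 log units; beyond the scatter), so compound 1 and compound 3 both carry a ring nitrogen on this chain and still lie well apart, and the presence of that nitrogen alone does not set the number. Nothing on hand accounts for the size of either step.

Compound 3 differs from compound 1 in both chain length and ring size, and the compounds shown cannot separate the two; a 3-(pyrrolidin-1-yl)propyl or a 2-(piperidin-1-yl)ethyl group on the same amine would do so. Also open, going by these compounds, is whether the longer chain counts without the ring nitrogen, which a 3-cyclohexylpropyl group would test, and whether a morpholin-4-yl ring at the end of the longer chain holds the number of compound 3.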